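A few compounds are considered here, and "the series" means these few. Any claim that something is new, unique, unknown or untested is made for them only; others in the source may bear on it.

Working notes on the series. The shared core of compound 1 `COc1n[nH]c2ncc(-c3ncc(-c4c(F)ccc(NS(=O)(=O)c5cccc(Cl)c5)c4F)[nH]3)cc12` is carried through to compound 2 `COc1n[nH]c2ncc(-c3cn(-c4c(Cl)ccc(NS(=O)(=O)c5cccc(Cl)c5)c4Cl)nn3)cc12` and compound 3 `COc1n[nH]c2ncc(-c3cn(-c4c(F)ccc(NS(=O)(=O)c5cccc(C#N)c5)c4F)nn3)cc12`; in an assay on Sf9 cells for inhibition of mitogen-activated protein kinase kinase kinase 20 (Homo sapiens), read by ADP-Glo, with a stated time of 30 min (a higher number here means a weaker inhibitor, a lower number a stronger inhibitor), compound 1 gives 983 nM, compound 2 gives 413 nM and compound 3 gives 3.3 nM. Compound 3 stands lowest of the three numbers: its gap to compound 2 and its larger gap to compound 1 both lie beyond the scatter, so compound 3 is the strongest inhibitor among the measured compounds.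

Compound 4 `COc1n[nH]c2ncc(-c3cn(-c4c(F)ccc(NS(=O)(=O)c5cccc6ccccc56)c4F)nn3)cc12` is not yet measured in this assay. It differs from compound 3 in one place: naphthalen-1-yl in place of 3-cyanophenyl on a sulfonyl sulfur. Among the compounds with values here, no measured pair shows this change, so its size can only be guessed. The nitrile-bearing ring of compound 3 is the only sulfonyl substituent that reaches a low number here, and the change removes it, so a weaker inhibitor is expected, by a step of a 6.1-fold higher number from compound 3 to compound 4 (0.78 log units; beyond the scatter) in this assay. For compound 4 the expected value in this assay is 20 nM, with a range from 4 nM to 120 nM.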

Compound 4, half-maximal inhibitory concentration: 4.2 nM
The estimate for compound 4 lay 4.8-fold (0.68 log units) above the measured number, and the stated range covers the measured number.
By their numbers in this assay, from the lowest: compounds 3 and 4 (each within the scatter of the next); then compound 2; then compound 1.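

In this assay the replacement of 3-cyanophenyl by naphthalen-1-yl on a sulfonyl sulfur gives a 1.3-fold higher number from compound 3 to compound 4 (0.10 log units; within the scatter) and so leaves the number in the same low range. Within the data shown here, the nitrile and the one hydrogen-bond acceptor counted in 3-cyanophenyl are therefore not required for a low number at this position, and a group with two six-membered aromatic rings of carbon only is accepted there, a point no earlier single-place step could show. No measurement shown accounts for the closeness of these two numbers.

Going by these compounds, whether the position keeps a low number with a non-aromatic group such as cyclohexyl or a short alkyl chain, or with a carboxylic acid or an amine on the ring, remains open. Also open, on these data alone, is how 3-chlorophenyl compares with these two groups on the core of compound 3.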